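The compounds below may be only part of what the source reports. "The series", "measured", "known", "first", "only" and "open" are said of these compounds alone.

Three amides built on a shared core have been measured in a functional assay on the whole organism (strain Wistar) for inhibition, with Rattus norvegicus as the target, read by paw edema, with a stated time of 3 h, at a dose of 100 mg/kg; a higher number here means more inhibition at the dose given (going by the name of the read-out), a lower number less inhibition. Compound 1 `COc1cc2c(cc1OC)C(CC(=O)Nc1ccccc1)CC2` gives 36.2%. Compound 2 `COc1cc2c(cc1OC)C(CC(=O)Nc1ccc(Cl)cc1)CC2` gives 60.9%, and compound 3 `COc1cc2c(cc1OC)C(CC(=O)Nc1ccc(C)cc1)CC2` gives 34.8%. Compound 3 stands lowest of the three numbers, though its distance from compound 1, a number 1.4 percentage points lower from compound 1 to compound 3 (within the scatter), lies within the scatter, while the step of a number 26.1 percentage points lower from compound 2 to compound 3 (beyond the scatter) lies beyond it. Compound 4 `COc1ccccc1NC(=O)CC1CCc2cc(OC)c(OC)cc21` has not yet been measured in this assay. It differs from compound 3 by 2-methoxyphenyl in place of 4-methylphenyl on an amide-type nitrogen. Within the data shown here, no measured step alters the aromatic group in this way. The steps that come nearest each replace a hydrogen on an aromatic carbon: a number 24.7 percentage points higher from compound 1 to compound 2 (beyond the scatter) brought a modest gain, whereas a number 1.4 percentage points lower from compound 1 to compound 3 (within the scatter) moved the number by nothing beyond the scatter. With no measured change resembling a methoxy group here, compound 4 is expected to show a step of about a number 5.2 percentage points higher from compound 3 to compound 4 (within the scatter), within the scatter. Compound 4 is therefore estimated to give 40%, with a range of 24% to 58%.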

Compound 4, a percentage reported as inhibition, in the whole organism at one dose (the size of the read-out at that dose, not a potency): 21.7%
Compound 4: the middle estimate sits 18.3 percentage points above what was measured; measured number below the stated range.
By their numbers in this assay, from the lowest: compound 4; then compounds 3 and 1 (each within the scatter of the next); then compound 2.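

Substitution on the aromatic group at the amide-type nitrogen can lower the number as well as raise it: methoxy in place of hydrogen gave a number 14.5 percentage points lower from compound 1 to compound 4 (beyond the scatter), a change beyond the scatter of a kind the methyl step had not produced. The 2-methoxyphenyl group also fell short of both para-free comparisons in the set, with 2-methoxyphenyl in place of 4-methylphenyl giving a number 13.1 percentage points lower from compound 3 to compound 4 (beyond the scatter) and 2-methoxyphenyl in place of 4-chlorophenyl giving a number 39.2 percentage points lower from compound 2 to compound 4 (beyond the scatter), so compound 4 now stands lowest of the four. Nothing available bears on why the number fell.

The compounds shown do not separate the methoxy group itself from where it sits on the aromatic ring. Going by these compounds, how a carboxylic acid or an amine on that ring would read also remains open.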